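Swapping the benzyl ring: a chloro-for-methoxy comparison

The source may hold more compounds than are shown below. What is called first, only, known or untested is meant among the compounds shown, and "the series" means these compounds.

Measured compounds:
Compound 1 `O=S(=O)(NCCCNCc1ccc(Cl)cc1)c1cc(C(F)(F)F)cc(C(F)(F)F)c1` gives 2800 nM in a functional assay on HT-29 cells (Homo sapiens) for inhibition, read by MTT assay, with a stated time of 72 h; a higher number here means a weaker inhibitor of growth, a lower number a stronger inhibitor of growth.
Compound 2 `COc1ccc(CNCCCNS(=O)(=O)c2cc(C(F)(F)F)cc(C(F)(F)F)c2)cc1OC` gives 2700 nM in this assay.

For the measured compounds named here, both compounds share a sulfonamide core joined through a three-carbon chain to an amine nitrogen, which carries a benzyl group; only that benzyl group differs. Compound 2 stands alongside compound 1 rather than apart from it: a 1.0-fold lower number from compound 1 to compound 2 (0.02 log units; within the scatter). So exchanging a 4-chlorophenyl for a 3,4-dimethoxyphenyl at this position made no difference that the assay can resolve.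

Compound 3 `O=S(=O)(NCCCNCc1cccc(Cl)c1)c1cc(C(F)(F)F)cc(C(F)(F)F)c1` has not yet been measured. It differs from compound 2 in one place: 3-chlorophenyl in place of 3,4-dimethoxyphenyl on a saturated chain carbon bound to an amine nitrogen. Going by the values given here, the only step that bears on this change is the one from compound 1 to compound 2, which was within the scatter, and compound 3 carries a chlorophenyl group much as compound 1 does. On that basis no step beyond the scatter is expected in this assay, and a 1.0-fold higher number from compound 2 to compound 3 (0.02 log units; within the scatter) is the expected outcome. Compound 3 is estimated at 2800 nM, with a plausible range from 1400 nM to 5600 nM.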

Compound 3, concentration for 50% growth inhibition: 14000 nM
The estimate for compound 3 lay 5.0-fold (0.70 log units) below the measured number, and the stated range ends below it.
By their numbers in this assay, from the lowest: compounds 2 and 1 (each within the scatter of the next); then compound 3.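

The two chlorinated compounds differ only in where the chlorine sits on the benzyl ring, and that alone matters in this assay: 3-chlorophenyl in place of 4-chlorophenyl gives a 5.0-fold higher number from compound 1 to compound 3 (0.70 log units; beyond the scatter), which means weaker inhibition of growth. The exchange with the dimethoxy compound tells the same story, with a 5.2-fold higher number from compound 2 to compound 3 (0.71 log units; beyond the scatter), so the position that seemed indifferent when only 4-chlorophenyl and 3,4-dimethoxyphenyl could be compared does respond to the group placed there, and a chlorine atom on the ring does not by itself fix the outcome. Nothing in the available data gives a measured reason for this loss of growth inhibition.

The compounds shown leave open whether the weaker result belongs to chlorine specifically or would also appear with another ring substituent, such as a fluorine, a bromine or a single methoxy group, and how an unsubstituted phenyl ring would compare. They also leave open whether the same difference between 3-chlorobenzyl and 4-chlorobenzyl would persist with a longer chain linking the benzyl amine to the shared core.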